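A few compounds are considered here, and "the series" means these few. Any claim that something is new, unique, unknown or untested is made for them only; others in the source may bear on it.

Working notes on the series, read in an ADME assay on cells (Homo sapiens) for cytotoxicity, read by resazurin assay, with a stated time of 5 days; a higher number here means that more compound is tolerated, a lower number that less compound is tolerated. Compound 1 `COc1ccc(-c2nc(C(C)S(=O)(=O)c3cccc(Cl)c3)nc3ccsc23)cn1` gives > 50000 nM, which is a limit and not a number. Compound 2 `COc1ccc(-c2nc(CNc3cccc(Cl)c3)nc3ccsc23)cn1` gives > 50000 nM, again a limit and not a number. Going by the values given here, compound 2 therefore has no exact value, and the only other measured compound offers no exact value to compare it with. The record so far is the limit of > 50000 nM in this assay, at which 2 of the 2 values shown sit.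

Compound 3 `COc1ccc(-c2nc(CSc3cccc(Br)c3)nc3ccsc23)cn1` departs from compound 2 by one change, (3-bromophenyl)sulfanyl in place of (3-chlorophenyl)amino on a saturated chain carbon bound to an aromatic carbon. Among the compounds with values here, no step between measured compounds is available to size this change. In this assay, the expectation is no shift beyond the scatter, with any small move going towards less compound tolerated. This expectation rests on compound 2 at > 50000 nM, a limit. The expected step is an at least 1.1-fold lower number from compound 2 to compound 3 (0.04 log units; that floor lies within the scatter). For compound 3, the estimate is 45000 nM, with an expected range from 20000 nM to 50000 nM.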

Compound 3, half-maximal cytotoxic concentration: > 50000 nM
Compound 3: a limit, no number; the forecaster's own chance of this, stated with the estimate: 65%; middle value at least 1.1-fold (0.04 log units) from the limit.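

Going by these compounds alone, compound 3, like compound 2, gives a limit and not a number in this assay, so no step between the two can be read. The record stands as follows: the limit of > 50000 nM in this assay, at which 3 of the 3 values shown sit.

The compounds shown leave open whether (3-bromophenyl)sulfanyl in place of (3-chlorophenyl)amino changes the tolerated concentration at all, and how far any compound lies from that limit.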